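The source may report more compounds than this note shows. Statements on the series, on what has been measured and on what is new or still open speak of the compounds shown alone.

Measured in a functional assay on HeLa cells (Homo sapiens) for antiproliferative activity, read by MTT assay, with a stated time of 48 h; on this read-out lower numbers stand for stronger inhibition and higher numbers for weaker inhibition:
- compound 1 `COc1ccc(-c2cc3c(cn2)[nH]c(=O)n3-c2cc(OC)c(OC)c(OC)c2)cc1`: 1210 nM
- compound 2 `COc1ccc(-c2cc3c(cn2)[nH]c(=O)n3-c2cc(OC)c(OC)c(OC)c2)cc1F`: 2210 nM
- compound 3 `COc1ccc(-c2cc3c(cn2)[nH]c(=O)n3-c2cc(OC)c(OC)c(OC)c2)cn1`: 870 nM

Compound 2 is the starting point here. Its value lies close to one of the others, a 1.8-fold higher number from compound 1 to compound 2 (0.26 log units; within the scatter), and a modest distance from the other, a 2.5-fold lower number from compound 2 to compound 3 (0.40 log units; beyond the scatter).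

Compound 4 `COc1ccc(-c2cc3c([nH]c(=O)n3-c3cc(OC)c(OC)c(OC)c3)c(C(N)=O)n2)cc1F` differs from compound 2 in one place, with carbamoyl in place of hydrogen on an aromatic carbon.

Within the data shown here, no measured step touches that carbon. All three steps alter the aromatic group elsewhere in the molecule, and the third of them, a 1.4-fold lower number from compound 1 to compound 3 (0.14 log units; within the scatter), is small as well. These steps are therefore only a weak guide, and they give no direction for the new change. With nothing pointing either way, no step beyond the scatter is expected in this assay, although the uncertainty is wide.

Compound 4 is estimated at 2500 nM, with an expected range from 500 nM to 12000 nM.

This estimate means an expected 1.1-fold higher number from compound 2 to compound 4 (0.05 log units; within the scatter).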

Compound 4, half-maximal inhibitory concentration: 330 nM
The estimate for compound 4 lay 7.6-fold (0.88 log units) above the measured number; measured number outside the range, below it.
By their numbers in this assay, from the lowest: compound 4; then compounds 3, 1 and 2 (each within the scatter of the next, the first and the last beyond it).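

In this assay, carbamoyl on the aromatic carbon next to the ring nitrogen gives a 6.7-fold lower number from compound 2 to compound 4 (0.83 log units; beyond the scatter). Among these compounds, the earlier steps all altered the aromatic group elsewhere in the molecule, so this is the first sign that this carbon of the shared core can carry an added group and that the number can move toward stronger inhibition when it does. No measurement available here explains why this change has that result.

Only one group at this carbon is shown, so it stays open whether a carboxylic acid, a nitrile or a methyl group would give a similar step. Carbamoyl also appears only with the 3-fluoro-4-methoxyphenyl group, so its step alongside the 4-methoxyphenyl group of compound 1 or the 6-methoxypyridin-3-yl group of compound 3 remains unknown.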